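Aryl hydrazone variation on a shared core in cell growth

The compounds below may be only part of what the source reports. "The series", "measured", "known", "first", "only" and "open" are said of these compounds alone.

Compound 1, `Cn1c(=O)c(=O)n(C2CCCC2)c2nc(N/N=C/c3ccc(O)c(F)c3)ncc21`, gives 59300 nM in a functional assay on HCT-116 cells (Homo sapiens) for antiproliferative activity, read by MTT assay; a lower number here means a stronger inhibitor, a higher number a weaker inhibitor.
Compound 2, `Cn1c(=O)c(=O)n(C2CCCC2)c2nc(N/N=C/c3ccco3)ncc21`, gives 78700 nM in this assay.
Compound 3, `Cn1c(=O)c(=O)n(C2CCCC2)c2nc(N/N=C/c3ccc(F)cc3Br)ncc21`, gives 8390 nM in this assay.

Compound 3 stands at the lowest number of the three. Its nearest neighbour is compound 1, reached by the step of a 7.1-fold lower number from compound 1 to compound 3 (0.85 log units; beyond the scatter), and its furthest is compound 2, reached by the step of a 9.4-fold lower number from compound 2 to compound 3 (0.97 log units; beyond the scatter). Between compounds 1 and 2 the step of a 1.3-fold higher number from compound 1 to compound 2 (0.12 log units; within the scatter) is within the scatter, so the two aryl groups they carry on the carbon with a double bond to nitrogen cannot be told apart in this assay.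

Compound 4, `Cn1c(=O)c(=O)n(C2CCCC2)c2nc(N/N=C/c3cccc([N+](=O)[O-])c3)ncc21`, differs from compound 3 in one place: 3-nitrophenyl in place of 2-bromo-4-fluorophenyl on a carbon with a double bond to nitrogen. Going by the values given here, no measured step involves a 3-nitrophenyl group, so the only steps that bear on it are the two that lead into compound 3, both modest, and both showing that changing the aryl group at this carbon can move the number by that much. Leaving the 2-bromo-4-fluorophenyl group is therefore expected to give back part of the gain seen in compound 3, with wide uncertainty. Compound 4 is estimated to give 30000 nM in this assay, within a range of 7000 nM to 120000 nM. This corresponds to an expected step of a 3.6-fold higher number from compound 3 to compound 4 (0.55 log units; beyond the scatter).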

Compound 4, half-maximal inhibitory concentration: 15200 nM
Compound 4: middle estimate off by 2.0-fold (0.30 log units), on the high side; low and high end bracket the measured number.
By their numbers in this assay, from the lowest: compounds 3 and 4 (each within the scatter of the next); then compounds 1 and 2 (each within the scatter of the next).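

The 3-nitrophenyl group puts a second aryl group at the carbon with a double bond to nitrogen into the low range of this assay. With a 1.8-fold higher number from compound 3 to compound 4 (0.26 log units; within the scatter), compound 3 and compound 4 cannot be told apart, although the entering group carries nitrogen and oxygen with 2 hydrogen-bond acceptors, and the leaving group carries fluorine and bromine with 0, so the low number is not confined to the 2-bromo-4-fluorophenyl group. The separation from the other two aryl groups also holds for the new group, with a 5.2-fold lower number from compound 2 to compound 4 (0.71 log units; beyond the scatter) and a 3.9-fold lower number from compound 1 to compound 4 (0.59 log units; beyond the scatter), both beyond the scatter but modest. No measurement on these compounds accounts for this grouping of the four numbers.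

What the nitro group and the bromine and fluorine atoms each contribute remains open, as the compounds shown include no unsubstituted phenyl group and no phenyl group carrying bromine alone or fluorine alone. As far as these compounds go, it also remains open how this position would respond to an aryl group carrying an amine or a carboxylic acid, or to a simple alkyl chain in place of the aryl group.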